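The compounds below may be only part of what the source reports. "The series", "measured", "known", "first", "only" and "open" are said of these compounds alone.

In a functional assay on HCT-15 cells (Homo sapiens) for inhibition (on this read-out higher numbers stand for weaker inhibition and lower numbers for stronger inhibition), three compounds that share a core have been measured. Compound 1 `Oc1ccccc1-c1cc(-c2cccc(F)c2)cc(-c2ccccc2O)n1` carries a 3-fluorophenyl group; in this assay compound 1 gives only a limit, > 50000 nM. Compound 2 `Oc1ccccc1-c1cc(-c2ccc(F)cc2)cc(-c2ccccc2O)n1` differs from compound 1 by 4-fluorophenyl in place of 3-fluorophenyl on an aromatic carbon; in this assay compound 2 likewise gives only a limit, > 50000 nM. Compound 3 `Oc1ccc(-c2cc(-c3cccc(F)c3)cc(-c3ccccc3O)n2)cc1` differs from compound 1 by 4-hydroxyphenyl in place of 2-hydroxyphenyl on an aromatic carbon; in this assay compound 3 also gives only a limit, > 50000 nM. The step that the two limits leave unreadable from compound 1 to compound 2 and the step that the two limits leave unreadable from compound 1 to compound 3 cannot be sized since (the limit of > 50000 nM in this assay, at which 3 of the 3 values shown sit). Compound 4 `Oc1ccc(-c2cc(-c3ccc(F)cc3)cc(-c3ccccc3O)n2)cc1` has not yet been measured; it differs from compound 3 by 4-fluorophenyl in place of 3-fluorophenyl on an aromatic carbon. Going by the values given here, this is the same kind of change as the one from compound 1 to compound 2, yet the surroundings differ: there the place is meta to two 2-hydroxyphenyl groups, here it is meta to a 2-hydroxyphenyl group and meta to a 4-hydroxyphenyl group. The expected step is a step that the limit leaves unreadable from compound 3 to compound 4, which rests on compound 3 giving only a limit, > 50000 nM. Compound 4 is therefore expected to sit near 80000 nM, most likely again reported as a limit, within a range from 20000 nM to 300000 nM.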

Compound 4, half-maximal inhibitory concentration: > 50000 nM
Compound 4 ended at the assay's limit; the forecaster's own chance of this, stated with the estimate: 85%; the middle value lies beyond the limit too.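

Neither the step from compound 3 to compound 4 nor the step from compound 2 to compound 4 can be read, because both compounds in each pair give only a limit, the same one: the limit of > 50000 nM in this assay, at which 4 of the 4 values shown sit.

The compounds shown leave open whether 4-fluorophenyl in place of 3-fluorophenyl, or 4-hydroxyphenyl in place of 2-hydroxyphenyl, changes inhibition in this assay at all.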